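Halogenated anilide as the next step from compound 3

The source may hold more compounds than are shown below. What is called first, only, known or untested is meant among the compounds shown, and "the series" means these compounds.

The three measured compounds share one core and differ only in the group on the amide-type nitrogen. Compound 1 `CCOC(=O)C1=Cc2ccccc2OC1(OCc1cn(CC(=O)NC2CCCCC2)nn1)C(F)(F)F` gives 11400 nM in a functional assay on HeLa cells (Homo sapiens) for inhibition, read by MTT assay, with a stated time of 24 h; on this read-out higher numbers stand for weaker inhibition and lower numbers for stronger inhibition. Compound 2 `CCOC(=O)C1=Cc2ccccc2OC1(OCc1cn(CC(=O)Nc2ccc(C)cc2)nn1)C(F)(F)F` gives 67400 nM in this assay, and compound 3 `CCOC(=O)C1=Cc2ccccc2OC1(OCc1cn(CC(=O)Nc2ccc(OC)cc2)nn1)C(F)(F)F` gives 31900 nM. Among these three numbers compound 3 stands second highest, closer to compound 2 than to compound 1. The two aryl amides both read weaker than the cyclohexyl amide: a 5.9-fold higher number from compound 1 to compound 2 (0.77 log units; beyond the scatter) and a 2.8-fold higher number from compound 1 to compound 3 (0.45 log units; beyond the scatter). Between the two aryl amides the swap on the aromatic carbon gave a 2.1-fold lower number from compound 2 to compound 3 (0.32 log units; beyond the scatter).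

Compound 4 `CCOC(=O)C1=Cc2ccccc2OC1(OCc1cn(CC(=O)Nc2ccc(I)cc2Cl)nn1)C(F)(F)F` carries the change (2-chloro-4-iodophenyl in place of 4-methoxyphenyl on an amide-type nitrogen). Among the measured compounds shown here, no measured step covers a halogenated aryl group on this nitrogen; the only step within the aryl series, from compound 2 to compound 3, was of modest size, and the aryl-for-cyclohexyl steps were larger but point away from compound 4's change. An expectation for compound 4 therefore rests on the aryl amides staying in the weak range, with a step of the modest kind seen so far in either direction, which is expressed as an expected 1.0-fold higher number from compound 3 to compound 4 (0.00 log units; within the scatter). Compound 4 is accordingly estimated at 32000 nM in this assay, with a range from 9000 nM to 120000 nM.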

Compound 4, half-maximal inhibitory concentration: 26100 nM
Beside the measured number, compound 4's estimate is 1.2-fold (0.09 log units) above it; the measured number falls inside the stated range.
By their numbers in this assay, from the lowest: compound 1; then compounds 4 and 3 (each within the scatter of the next); then compound 2.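

In this assay, among the compounds shown here, the first halogenated aryl group on the amide-type nitrogen, 2-chloro-4-iodophenyl in place of 4-methoxyphenyl, leaves the reading within the scatter (a 1.2-fold lower number from compound 3 to compound 4 (0.09 log units; within the scatter)), so this large change of substituents on the aryl ring has no resolvable effect in this comparison. The same group still separates from 4-methylphenyl (a 2.6-fold lower number from compound 2 to compound 4 (0.41 log units; beyond the scatter)) and from cyclohexyl (a 2.3-fold higher number from compound 1 to compound 4 (0.36 log units; beyond the scatter)), which extends the earlier picture: compound 2, compound 3 and compound 4 all read weaker than the cyclohexyl amide, and none of the compounds shown goes against this. Nothing given here bears on why these groups read as they do.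

As far as these compounds go, what a lone 2-chlorophenyl or a lone 4-iodophenyl group would read on this nitrogen stays open, so the contributions of the chlorine and the iodine cannot be told apart. Also open, from the compounds shown here alone, is whether the stronger reading of the cyclohexyl amide carries over to other saturated groups such as cyclopentyl or a longer alkyl chain, and how an aryl group bearing an amine or a carboxylic acid would read.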